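Swapping the amide substituent on the shared core

The compounds below may be only part of what the source reports. "The series", "measured", "known", "first", "only" and "open" are said of these compounds alone.

In an ADME assay on MT4 cells (Homo sapiens) for cytotoxicity, read by MTT assay (on this read-out lower numbers stand for higher toxicity in this test and higher numbers for lower toxicity in this test), compound 1 (`O=C(CSc1nncnc1-c1ccccc1Cl)Nc1ccccc1Br`) gives 73000 nM and compound 2 (`Cc1ccc2sc(NC(=O)CSc3nncnc3-c3ccccc3Cl)nc2c1`) gives 137000 nM, two values within the scatter of each other. Compound 3 (`COC(=O)c1sccc1NC(=O)CSc1nncnc1-c1ccccc1Cl`) carries 2-(methoxycarbonyl)thiophen-3-yl in place of 2-bromophenyl on an amide-type nitrogen. Among the compounds with values here, no measured step covers such a change, so only these two values can guide the expectation. The expected change in this assay is slightly upward and no larger than the scatter, an estimated step of a 1.4-fold higher number from compound 1 to compound 3 (0.14 log units; within the scatter). The estimate for compound 3 is 100000 nM, with an expected range of 40000 nM to 250000 nM.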

Compound 3, half-maximal cytotoxic concentration: 105000 nM
Estimate against measurement, compound 3: 1.1-fold (0.02 log units) below; measured number inside the range.
By their numbers in this assay, from the lowest: compounds 1, 3 and 2 (each within the scatter of the next).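

Within the data shown here, at the amide-type nitrogen, the step from 2-bromophenyl to 2-(methoxycarbonyl)thiophen-3-yl is the only one-place change available in this assay (a 1.4-fold higher number from compound 1 to compound 3 (0.16 log units; within the scatter)), and it stays within the scatter. This position therefore takes a five-membered aromatic ring with 1 hetero atom and a methoxycarbonyl group without a shift beyond the scatter in this read-out. Nothing measured here explains this result.

Going by these compounds, whether a carboxylic acid in place of the methoxycarbonyl group would move the number beyond the scatter stays open. The same holds for an amine on the ring or a plain alkyl chain in place of the ring.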